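Replacing cyano with amino in compound 2

A few compounds are considered here, and "the series" means these few. Any claim that something is new, unique, unknown or untested is made for them only; others in the source may bear on it.

In an ADME assay on the whole organism (muscle tissue) for activation, with Mus musculus as the target, in the rotarod test, with a stated time of 30 min (on this read-out higher numbers stand for an effect only at larger amounts of compound and lower numbers for an effect already at smaller amounts), compound 2 (`N#Cc1ccc(-c2ccc(/C=N/N3C(=O)NC(=O)C3O)o2)cc1`) gives 96 mg/kg as its reading. Compound 3 (`O=C1CN(/N=C/c2ccc(-c3cccc(C(F)(F)F)c3)o2)C(=O)N1`) gives 166 mg/kg. The gap between compound 2 and compound 3 lies within the usual scatter. Compound 1 (`O=C1NC(=O)N(/N=C/c2ccc(-c3ccc(Cl)c(Cl)c3)o2)C1O`) gives 10 mg/kg. The gap between compound 1 and compound 2 lies beyond the usual scatter, with compound 1 on the low side, where a smaller amount is enough for the effect.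

Compound 4 (`Nc1ccc(-c2ccc(/C=N/N3C(=O)NC(=O)C3O)o2)cc1`) carries amino in place of cyano on an aromatic carbon, para to a large group (amino in place of cyano on an aromatic carbon). Everything else in compound 4 matches compound 2, so compound 2 at 96 mg/kg serves as the anchor for an expectation. For the measured compounds named here, no measured pair shows this exchange, and the data give no direction for it. In this assay no shift beyond the scatter is therefore expected. The estimated step is a 1.2-fold lower number from compound 2 to compound 4 (0.08 log units; within the scatter) and it is expected to stay small. For compound 4 the estimated value is 80 mg/kg (25 mg/kg to 250 mg/kg).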

Compound 4, dose for half-maximal effect: > 1000 mg/kg
Compound 4 was reported as a limit; the forecaster's own chance of this, stated with the estimate: 10%; middle value at least 12-fold (1.09 log units) away from the limit.
By their numbers in this assay, from the lowest: compound 1; then compounds 2 and 3 (each within the scatter of the next). At a limit, above all of these: compound 4.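

In this assay, the group on this aromatic carbon, para to a large group, proves far from indifferent: amino in place of cyano gives an at least 10-fold higher number from compound 2 to compound 4 (1.01 log units; beyond the scatter). Compound 4 stands at a limit rather than at a number: the limit of > 1000 mg/kg in this assay, at which 1 of the 4 values shown sits. For the compounds shown here, the earlier compounds offered no step that differs in one place, and this pair is the first to show that a change at this position alone can move the reading this far.

As far as these compounds go, how far past the limit compound 4 lies stays open, as does whether the step follows from amino entering or from cyano leaving. Nor do the compounds shown tell whether a hydroxyl, a methyl or a carboxylic acid at this position would read near compound 2 or at the same limit.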